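Thiophene for fluorophenyl on the acylthiourea of compound 2

The source may hold more compounds than are shown below. What is called first, only, known or untested is meant among the compounds shown, and "the series" means these compounds.

Measured compounds:
compound 1 `NC(=S)n1ccc2c(OCCCCCOc3ccc(Cl)cc3)cccc21` with 24700 nM
compound 2 `O=C(NC(=S)N1CCc2c(OCCCCCOc3ccc(Cl)cc3)cccc21)c1ccc(F)cc1` with 31100 nM
compound 3 `O=C(NC(=S)N1CCc2c(OCCCCCOc3ccc(Cl)cc3)cccc21)c1ccco1` with 4620 nM

Compound 2 has the highest number of the three in an ADME assay on Huh-7 cells (Homo sapiens) for cytotoxicity; a higher number here means that more compound is tolerated, a lower number that less compound is tolerated; its value and that of compound 1 lie within the scatter of each other, while compound 3 sits clearly below it, by a 6.7-fold lower number from compound 2 to compound 3 (0.83 log units; beyond the scatter). The unmeasured compound 4 `O=C(NC(=S)N1CCc2c(OCCCCCOc3ccc(Cl)cc3)cccc21)c1cccs1` differs from compound 2 in one place: thiophen-2-yl in place of 4-fluorophenyl on a carbonyl carbon. Among the compounds with values here, the only measured step that bears on this change is the one from compound 2 to compound 3, where another five-membered aromatic ring with 1 hetero atom entered at the same carbonyl carbon and the number fell by a 6.7-fold lower number from compound 2 to compound 3 (0.83 log units; beyond the scatter). Within the data shown here, by that analogy compound 4 is expected to show a lower number than compound 2 in this assay, though the single precedent leaves the size uncertain. The step from compound 2 to compound 4 is estimated at a 3.5-fold lower number from compound 2 to compound 4 (0.54 log units; beyond the scatter). For compound 4 the expected value is 9000 nM, within a range from 3000 nM to 27000 nM.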

Compound 4, half-maximal cytotoxic concentration: 10700 nM
For compound 4 the middle estimate is 1.2-fold (0.08 log units) below the measured one; the measured number falls inside the stated range.
By their numbers in this assay, from the lowest: compound 3; then compound 4; then compounds 1 and 2 (each within the scatter of the next).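

In this assay, thiophen-2-yl in place of 4-fluorophenyl on the carbonyl carbon gives a 2.9-fold lower number from compound 2 to compound 4 (0.46 log units; beyond the scatter) and so goes the same way as the furan-2-yl of compound 3, which makes two five-membered aromatic rings with 1 hetero atom that fall below compound 2 at this position. The two rings are not interchangeable, however: thiophen-2-yl in place of furan-2-yl gives a 2.3-fold higher number from compound 3 to compound 4 (0.36 log units; beyond the scatter). This leaves compound 4 clearly between compound 3 and compound 2, so the size of the fall depends on which ring enters. Nothing measured here explains either step.

The compounds shown leave open whether the fall follows the five-membered ring itself or the loss of the fluorine from the 4-fluorophenyl. An unsubstituted phenyl or a saturated cyclopentyl on the same carbonyl carbon would help to separate these two readings.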